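Cyclopropylcarbonyl for 2-hydroxyethyl on an aromatic oxygen

The compounds below may be only part of what the source reports. "The series", "measured", "known", "first", "only" and "open" are said of these compounds alone.

compound 1 `C=CCOc1cc(/C=C/C(=O)c2ccc(OC)c3c2OC(C)(C)C=C3)ccc1OC`: > 20000 nM
compound 2 `COc1ccc(/C=C/C(=O)c2ccc(OC)c3c2OC(C)(C)C=C3)cc1OCCO`: > 10000 nM
compound 3 `COc1ccc(/C=C/C(=O)c2ccc(OC)c3c2OC(C)(C)C=C3)cc1OC(=O)CCl`: > 10000 nM

These readings come from an ADME assay on L02 cells (Homo sapiens) for cytotoxicity, read by MTT assay; on this read-out higher numbers stand for weaker inhibition and lower numbers for stronger inhibition. Compound 2 has no number, only a limit, and it stands at the limit of > 10000 nM in this assay, at which 2 of the 3 values shown sit. Compound 1 also has only a limit, and it stands at the limit of > 20000 nM in this assay, at which 1 of the 3 values shown sits. Compound 3 likewise has only a limit.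

The step followed here leads to compound 4 `COc1ccc(/C=C/C(=O)c2ccc(OC)c3c2OC(C)(C)C=C3)cc1OC(=O)C1CC1`, in which cyclopropylcarbonyl stands in place of 2-hydroxyethyl on an oxygen on an aromatic ring: cyclopropylcarbonyl in place of 2-hydroxyethyl on an oxygen on an aromatic ring.

Among the compounds with values here, three measured steps bear on this change, and none has a readable size. The closest is a step that the two limits leave unreadable from compound 2 to compound 3, which replaces the same 2-hydroxyethyl with (chloromethyl)carbonyl. The other two are a step that the two limits leave unreadable from compound 1 to compound 2 and a step that the two limits leave unreadable from compound 1 to compound 3. With no measured size to carry over, no step beyond the usual scatter is expected in this assay, in either direction. The expectation is anchored on compound 2, whose > 10000 nM is a limit. The expected step is a step that the limit leaves unreadable from compound 2 to compound 4. For compound 4 the estimated value is 20000 nM, with an expected range from 8000 nM to 50000 nM.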

Compound 4, half-maximal inhibitory concentration: > 10000 nM
Compound 4 ended at the assay's limit; the forecaster's own chance of this, stated with the estimate: 80%; the middle value lies beyond the limit too.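

In this assay compound 4 gives > 10000 nM, which is a limit and not a number. Within the data shown here, compound 1, compound 2 and compound 3 also stand only at limits, so no step from any of them to compound 4 can be read. The compounds shown leave open whether any of the four differs from the others in this assay.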